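This account rests on a few compounds, and the source may have more. Where it says the series, first, only, none or still open, it means among the compounds named here.

Measured compounds:
compound 1, `Cc1cccc(/C(N)=N/NC(=S)N2CCSCC2)n1`: 51.7%
compound 2, `N/C(=N\NC(=S)N1CCSCC1)c1ccccn1`: 37.2%
compound 3, `N/C(=N\NC(=S)N1CCCCC1)c1ccccn1`: 27%

All three were tested in a functional assay on A-431 cells (Homo sapiens) for cytotoxicity, read by MTT assay, with a stated time of 72 h, tested at 3 uM; on this read-out lower numbers stand for less inhibition of growth and higher numbers for more inhibition of growth at the one concentration tested. Compound 2 is the point of comparison. The step of a number 14.5 percentage points higher from compound 2 to compound 1 (beyond the scatter) goes with the change (methyl in place of hydrogen on an aromatic carbon). The step of a number 10.2 percentage points lower from compound 2 to compound 3 (beyond the scatter) goes with piperidin-1-yl in place of thiomorpholin-4-yl on a thiocarbonyl carbon, which is also how the core of compound 3 differs from the core of compound 2; compound 3 gives the lowest of the three numbers. Compound 4, `Cc1ccnc(/C(N)=N/NC(=S)N2CCCCC2)c1`, is not yet measured and differs from compound 3 by methyl in place of hydrogen on an aromatic carbon. This is the same kind of change as that from compound 2 to compound 1, but not the same: there the methyl is next to the ring nitrogen, here it is opposite the ring nitrogen, in both cases meta to a large group. Because the earlier step of a number 14.5 percentage points higher from compound 2 to compound 1 (beyond the scatter) was modest and the place is not the same, compound 4 is expected to gain in this assay by a smaller step of a number 10 percentage points higher from compound 3 to compound 4 (within the scatter). Compound 4 is thus estimated at 37%, between 22% and 52%.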

Compound 4, percent growth inhibition at one concentration: 36.5%
Beside the measured number, compound 4's estimate is 0.5 percentage points above it; the range from low to high includes it.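

In this assay, methyl in place of hydrogen on an aromatic carbon goes with a number 9.5 percentage points higher from compound 3 to compound 4 (within the scatter). Set beside the earlier step, the same change on the other core cannot be told apart from it: the same change on two cores in this assay, a number 14.5 percentage points higher (beyond the scatter) from compound 2 to compound 1 and a number 9.5 percentage points higher (within the scatter) from compound 3 to compound 4, 5 percentage points apart, within the scatter of two such steps. Within the data shown here, this does not show that the step holds generally: only two cores are compared, the methyl does not stand at the same place on them, and the new step alone lies within the scatter.

The compounds shown leave open how an ethyl, a methoxy or a chlorine opposite the ring nitrogen would compare with the methyl. They also leave open whether the change carries over to a core with morpholin-4-yl in place of piperidin-1-yl.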